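Dropping the ethylsulfonyl group from compound 1

The compounds below may be only part of what the source reports. "The series", "measured", "known", "first", "only" and "open" are said of these compounds alone.

Compound 1 `CCS(=O)(=O)Nc1cccc2c1CCCC2c1c[nH]cn1` is the weakest of three measured compounds in an assay on isolated protein for binding affinity to Alpha-2B adrenergic receptor (Rattus norvegicus), read by radioligand binding (a lower number here means a stronger inhibitor, a higher number a weaker inhibitor), giving 1700 nM. Compound 3 `CCS(=O)(=O)Nc1cccc(Cc2c[nH]cn2)c1` gives 977 nM, a number within the scatter of compound 1, so the two cannot be ranked. Compound 2 `CS(=O)(=O)Nc1c(O)ccc2c1CCCC2c1c[nH]cn1`, which carries a hydroxyl group and a methylsulfonyl group, gives 47.9 nM, a far lower number and the only clear difference among the three.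

Compound 4 `Nc1cccc2c1CCCC2c1c[nH]cn1` differs from compound 1 by hydrogen in place of ethylsulfonyl on a nitrogen on an aromatic ring. Among the measured compounds shown here, no measured pair shows this change, so its effect is open. The expected step of a 1.8-fold higher number from compound 1 to compound 4 (0.25 log units; within the scatter) is a modest move toward weaker binding, with wide uncertainty. Compound 4 is thus estimated at 3000 nM, within a range from 800 nM to 12000 nM.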

Compound 4, inhibition constant: 49 nM
Beside the measured number, compound 4's estimate is 61-fold (1.79 log units) above it; measured number below the stated range.
By their numbers in this assay, from the lowest: compounds 2 and 4 (each within the scatter of the next); then compounds 3 and 1 (each within the scatter of the next).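

Putting hydrogen in place of ethylsulfonyl on a nitrogen on an aromatic ring gives a 35-fold lower number from compound 1 to compound 4 (1.54 log units; beyond the scatter) in this assay, a large move toward stronger binding. Among the compounds shown here, this is the only pair here that differs in one place, and it shows that on this core the ethylsulfonyl group is not needed for binding and that the plain amino group does far better. Nothing available explains the size of this step. The compounds shown leave open how a small group on this nitrogen, such as methyl or acetyl, would compare. They therefore cannot tell whether any substituent there weakens binding or only one as large as ethylsulfonyl.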